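The source may hold more compounds than are shown below. What is called first, only, known or untested is meant among the compounds shown, and "the series" means these compounds.

Compound 1, `CCC[C@@H](OC(C)=O)C1=C(Br)[C@@](OC)(C(Br)Br)OC1=O`: 4.1 ug/mL
Compound 2, `CCCCC1=C(Br)/C(=C/Br)OC1=O`: a limit, > 20 ug/mL

In a functional assay on KB cells (Homo sapiens) for cytotoxicity (on this read-out higher numbers stand for an effect only at larger amounts of compound and lower numbers for an effect already at smaller amounts), compound 1 gives 4.1 ug/mL. For compound 2 this assay reports only a limit, > 20 ug/mL, so no number can be set against it. Within the data shown here, compound 1 therefore stands as the only compound with a number in this assay, because of the limit of > 20 ug/mL in this assay, at which 1 of the 2 values shown sits.

Compound 3, `CCC[C@@H](OC(C)=O)C1=C(Br)[C@](OC)(C(Br)Br)OC1=O`, has not been measured in this assay. It differs from compound 1 as follows: the two compounds have the same atoms and bonds and differ only in configuration as drawn: 1 of 2 stereo elements differ; a stereocentre at a saturated ring carbon is drawn S in compound 1 and R in compound 3. Among the measured compounds shown here, no pair of measured compounds separated by a single change is available, so no measured step can be carried over. The atoms and bonds are unchanged and only the configuration at the saturated ring carbon is drawn differently; a step no larger than the usual scatter is expected from compound 1 to compound 3 in this assay, with a wider margin left for a loss of effect.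

Compound 3 is thus expected to give about 6 ug/mL in this assay, within 2 ug/mL to 20 ug/mL. This means an expected step of a 1.5-fold higher number from compound 1 to compound 3 (0.17 log units; within the scatter).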

Compound 3, concentration for half-maximal effect: 6.1 ug/mL
The estimate for compound 3 lay 1.0-fold (0.01 log units) below the measured number; the range from low to high includes it.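

In this assay, among these compounds, the first step that can be read at all is this change of drawn configuration at the saturated ring carbon, and it comes to a 1.5-fold higher number from compound 1 to compound 3 (0.17 log units; within the scatter). The earlier compounds shown here offered no such reading, since they gave one number and one limit, whereas this pair sets two numbers side by side. At this position, therefore, the S and R drawings are not told apart by this read-out, and the comparison is a clean one, with nothing else in the structure to account for the step: the fact that compounds 1 and 3 differ only in the configuration as drawn

What the compounds leave open is whether the other stereo element, kept as drawn in this pair, would be equally silent if its configuration were the one to differ. Also open, on these data alone, is whether the same lack of separation would hold with a different group on the saturated ring carbon, such as a hydroxyl group or an amine in place of the methoxy group, since the present pair speaks only for the core of compound 1 as it stands.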